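A few compounds are considered here, and "the series" means these few. Any claim that something is new, unique, unknown or untested is made for them only; others in the source may bear on it.

Compound 1 `Cc1ccccc1-n1nc(C)c2c1NC(=O)[C@H](C)S[C@@H]2c1ccc(Oc2ccccc2)cc1` is the starting point, and in an assay on isolated protein for agonist activity at Bile acid receptor (Homo sapiens), read by AlphaScreen, with a stated time of 30 min (a higher number here means that more compound is needed for the effect, a lower number that less compound is needed), compound 1 gives 1300 nM. Among the three measured compounds, compound 1 has the highest number, but its gaps to the other two lie within the scatter, so no order can be read from them. Compound 2 `CCc1ccccc1-n1nc(C)c2c1NC(=O)[C@H](C)S[C@@H]2c1ccc(Oc2ccccc2)cc1` gives 1100 nM in this assay, and compound 3 `CCCc1ccccc1-n1nc(C)c2c1NC(=O)[C@H](C)S[C@@H]2c1ccc(Oc2ccccc2)cc1` gives 1100 nM. The steps of a 1.2-fold lower number from compound 1 to compound 2 (0.07 log units; within the scatter) and a 1.2-fold lower number from compound 1 to compound 3 (0.07 log units; within the scatter) replace hydrogen on a saturated chain carbon bound to an aromatic carbon with methyl or ethyl and leave the number where it was, and the step of no change at the digits printed from compound 2 to compound 3 (within the scatter) says the same. Compound 4 `COc1ccc(Oc2ccc([C@H]3S[C@@H](C)C(=O)Nc4c3c(C)nn4-c3ccccc3C)cc2)cc1` differs from compound 1 at another place: methoxy in place of hydrogen on an aromatic carbon. Going by the values given here, no measured pair alters the phenoxy part of the shared core, so none of the measured steps bears directly on this change; they show only that small additions elsewhere on the core did not move the number beyond the scatter. Among the compounds with values here, with no direct precedent, a step close to zero is the most reasonable expectation, with a wide range on either side. Compound 4 is therefore estimated at 1200 nM, within 400 nM to 3500 nM, which corresponds to an expected step of a 1.1-fold lower number from compound 1 to compound 4 (0.03 log units; within the scatter).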

Compound 4, half-maximal effective concentration: 2200 nM
For compound 4 the middle estimate is 1.8-fold (0.26 log units) below the measured one; the range from low to high includes it.
By their numbers in this assay, from the lowest: compounds 2, 3, 1 and 4 (each within the scatter of the next).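

Going by these compounds alone, replacing phenoxy with 4-methoxyphenoxy gives a 1.7-fold higher number from compound 1 to compound 4 (0.23 log units; within the scatter), and this is the first measured change to the phenoxy part of the shared core. In this assay, then, a methoxy group on this six-membered aromatic ring of carbon only, para to a large group, is accepted without a shift that can be told apart from the ordinary variation between repeated measurements, so compound 4 and compound 1 cannot be ranked. No accompanying measurement bears on this result, so the data offer no explanation for it.

On these data alone, a single substituent cannot show how far this position stays insensitive, so it remains open whether a longer ether such as ethoxy or benzyloxy, a fluorine atom, an amine or a carboxylic acid at the same place would move the number beyond the scatter. Also open, as far as these compounds go, is whether methoxy on another carbon of that ring would read the same, and whether this addition would behave alike on compound 2 or compound 3.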